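The source may hold more compounds than are shown below. What is called first, only, known or untested is meant among the compounds shown, and "the series" means these compounds.

Three hydroxamic acids were examined in an assay on Sf9 cells for inhibition of histone deacetylase 8 (Homo sapiens), read by mobility shift assay; on this read-out higher numbers stand for weaker inhibition and lower numbers for stronger inhibition. Compound 1, `CC(C)(C)c1ccc(CN(C(=O)CN(Cc2c(F)c(F)c(F)c(F)c2F)S(=O)(=O)c2ccc(F)cc2)c2ccc(C(=O)NO)cc2)cc1`, was measured first in this series of results; in this assay compound 1 reaches only the limit of > 1000 nM, which is a boundary of the measurement and not a number. Compound 2, `O=C(NO)c1ccc(N(Cc2ccc(C(F)(F)F)cc2)C(=O)CN(Cc2c(F)c(F)c(F)c(F)c2F)S(=O)(=O)c2ccc(F)cc2)cc1`, shares the whole framework of compound 1 apart from a single group. For compound 2 this assay likewise gives only a limit, > 1000 nM. Compound 3, `O=C(NO)c1ccc(N(Cc2ccc(C(F)(F)F)cc2)C(=O)CN(Cc2ccccc2C(F)(F)F)S(=O)(=O)c2ccc(F)cc2F)cc1`, carries a different arrangement on the sulfonamide side; how its core differs from that of compound 2 is not broken down here. For compound 3 too the result in this assay is a limit, > 1000 nM.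

Among the compounds with values here, the one counted change between the measured pair is tert-butyl in place of trifluoromethyl on an aromatic carbon, and the step that the two limits leave unreadable from compound 2 to compound 1 cannot be read as a size, because of the limit of > 1000 nM in this assay, at which 3 of the 3 values shown sit.

Compound 4, `CC(C)(C)c1ccc(CN(C(=O)CN(Cc2ccccc2C(F)(F)F)S(=O)(=O)c2ccc(F)cc2F)c2ccc(C(=O)NO)cc2)cc1`, stands to compound 3 exactly as compound 1 stands to compound 2: the change is tert-butyl in place of trifluoromethyl on an aromatic carbon, the same change in the same place. Since the earlier instance of this change could not be sized, and all three measured compounds sit at the limit of this assay, the step that the limit leaves unreadable from compound 3 to compound 4 is expected to be small or unreadable. Compound 4 is therefore estimated to come in at around 3000 nM, with a plausible range from 800 nM to 20000 nM, most likely again reported only as a limit.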

Compound 4, half-maximal inhibitory concentration: > 1000 nM
Compound 4: no number, only a limit; the forecaster's own chance of this, stated with the estimate: 80%; the middle value lies beyond the limit too.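

In this assay compound 4 gives > 1000 nM, which is a limit and not a number. No size can be read for the change from compound 3 to compound 4, because the result again rests on the boundary of the measurement: the limit of > 1000 nM in this assay, at which 4 of the 4 values shown sit.

The compounds shown leave open how strongly compound 1, compound 2, compound 3 and compound 4 actually inhibit the enzyme, and whether tert-butyl in place of trifluoromethyl alters that inhibition at all.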